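The source may report more compounds than this note shows. Statements on the series, on what has been measured and on what is new or still open speak of the compounds shown alone.

Compound 1, `O=c1sc2cc(N(S(=O)(=O)c3ccccc3)S(=O)(=O)c3ccccc3)ccc2n1CCN1CCCC1`, gives 20% in an assay on HEK293 cells for displacement of a labelled ligand from 5-hydroxytryptamine receptor 6 (Homo sapiens), read by radioligand binding, with a stated time of 60 min, tested at 100 nM; on this read-out higher numbers stand for more inhibition at the one concentration tested (going by the name of the read-out) and lower numbers for less inhibition.
Compound 2, `CN(C)CCn1c(=O)sc2cc(NS(=O)(=O)c3ccccc3)ccc21`, gives 5% in this assay.
Compound 3, `O=c1sc2cc(NS(=O)(=O)c3ccccc3)ccc2n1CCN1CCCC1`, gives 11% in this assay.

Compound 3 has the second highest of the three numbers. Its nearest neighbour is compound 2, and the step of a number 6 percentage points higher from compound 2 to compound 3 (within the scatter) lies within the scatter; the step of a number 9 percentage points lower from compound 1 to compound 3 (within the scatter) likewise lies within the scatter, so none of the three compounds can be set apart from the others on these data.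

Compound 4, `O=c1sc2cc(NS(=O)(=O)c3ccccc3)ccc2n1CCN1CCCCC1`, differs from compound 3 in one place: piperidin-1-yl in place of pyrrolidin-1-yl on a saturated chain carbon, two bonds along the chain from an aromatic nitrogen. Among the measured compounds shown here, of the measured steps, only the one from compound 2 to compound 3 bears on this change, since it also replaced the amine on the saturated chain carbon, two bonds along the chain from the aromatic nitrogen, and that step, a number 6 percentage points higher from compound 2 to compound 3 (within the scatter), stayed within the scatter. For the measured compounds named here, no measured step shows a ring of a different size at this place. For compound 4 the expected step in this assay is therefore a number 1 percentage points higher from compound 3 to compound 4 (within the scatter), that is, no change beyond the scatter. Compound 4 is estimated at 12%, with a range from 0% to 30%.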

Compound 4, a percentage reported as inhibition, at one concentration (the size of the read-out at that concentration, not a potency): 6%
For compound 4 the middle estimate is 6 percentage points above the measured one, and the stated range covers the measured number.
By their numbers in this assay, from the lowest: compounds 2, 4, 3 and 1 (each within the scatter of the next, the first and the last beyond it).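

Piperidin-1-yl in place of pyrrolidin-1-yl on a saturated chain carbon, two bonds along the chain from an aromatic nitrogen, is the first change of ring size at this place, and in this assay it gives a number 5 percentage points lower from compound 3 to compound 4 (within the scatter). Set against the open-chain amine, the same ring gives a number 1 percentage points higher from compound 2 to compound 4 (within the scatter), so dimethylamino, pyrrolidin-1-yl and piperidin-1-yl cannot be told apart at this place on these numbers. Nothing available explains these small differences or the lack of a clear effect of the ring.

The compounds shown leave open whether morpholin-4-yl at this place, or a longer chain carrying the amine, would move the number beyond the scatter. They also leave open whether a chloro or methoxy group on the phenyl ring of the phenylsulfonyl group would do so.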